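A few compounds are considered here, and "the series" means these few. Any claim that something is new, unique, unknown or untested is made for them only; others in the source may bear on it.

Measured in a functional assay on MCF7 cells (Homo sapiens) for antiproliferative activity, read by MTT assay, with a stated time of 24 h; on this read-out lower numbers stand for stronger inhibition and higher numbers for weaker inhibition:
- compound 1 `CNC(=O)c1ccccc1Oc1nc(Nc2ccc(C(F)(F)F)cc2)ncc1Br`: > 50000 nM (a limit)
- compound 2 `CNC(=O)c1ccccc1Oc1nc(Nc2ccccc2F)ncc1Br`: > 50000 nM (a limit)
- compound 3 `CNC(=O)c1ccccc1Oc1nc(Nc2cccc(Br)c2)ncc1Br`: 42500 nM

Compound 2 has no number to its name, only the limit > 50000 nM. The picture so far is the limit of > 50000 nM in this assay, at which 2 of the 3 values shown sit. Among the three, compound 3 alone gives a number, 42500 nM.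

The next change leads to compound 4 `CNC(=O)c1ccccc1Oc1nc(Nc2ccc(C)cc2C)ncc1Br`, with 2,4-dimethylphenyl in place of 2-fluorophenyl on a nitrogen on an aromatic ring. The place is the same one that varies among the measured compounds. Within the data shown here, the only measured step there is an at least 1.1-fold lower number from compound 2 to compound 3 (0.07 log units; that floor lies within the scatter). That step is small and rests on a limit, so it gives no ground for expecting a large move in either direction. No group tried at this place has yet given a strong value in this assay, and no step beyond the scatter is expected here. Compound 4 may well be reported only as a limit too.

The expected step, an estimate resting on this one measured step, is an at least 1.1-fold lower number from compound 2 to compound 4 (0.04 log units; that floor lies within the scatter). The estimated value for compound 4 is 45000 nM. The expected range for compound 4 runs from 20000 nM to 80000 nM.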

Compound 4, half-maximal inhibitory concentration: 44700 nM
Beside the measured number, compound 4's estimate is 1.0-fold (0.00 log units) above it; measured number inside the range.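

In this assay, among these compounds, 2,4-dimethylphenyl is the first group at this place that carries no halogen, and compound 4 is the second compound to give a number rather than a limit. The change gives an at least 1.1-fold lower number from compound 2 to compound 4 (0.04 log units; that floor lies within the scatter), and it gives a 1.1-fold higher number from compound 3 to compound 4 (0.02 log units; within the scatter), so the two methyl groups and the single bromine of 3-bromophenyl cannot be told apart in this read-out. Taking the halogen off the phenyl ring therefore brings no step beyond the scatter, and the series stays at the edge of the tested range: the limit of > 50000 nM in this assay, at which 2 of the 4 values shown sit.

Going by these compounds, whether any group on this nitrogen can move the number beyond the scatter remains open, and an amine, a carboxylic acid or a longer chain on the phenyl ring would put that to the test. Compound 1 and compound 2 stand only as limits, so their distance from the measured compounds cannot be read, and the compounds shown say nothing about changes to the rest of the shared core.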